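The source may report more compounds than this note shows. Statements on the series, on what has been measured and on what is new or still open speak of the compounds shown alone.

Series notes. Compound 1 `NNC(=O)c1c(NC(=O)NS(=O)(=O)c2ccccc2)sc2c1CCCCC2` carries an aminoamino group on the carbonyl carbon of the shared core; compound 2 `O=C(Nc1sc2c(c1C(=O)N1CCN(c3ccccc3)CC1)CCCCC2)NS(=O)(=O)c1ccccc1` carries 4-phenylpiperazin-1-yl there instead. In a functional assay on NSCLC cells (Homo sapiens) for inhibition, with a stated time of 48 h (on this read-out lower numbers stand for stronger inhibition of growth and higher numbers for weaker inhibition of growth), compound 1 gives 10500 nM and compound 2 gives 36200 nM, so compound 2 stands at the weaker end of the two measured numbers; the change a 3.4-fold higher number from compound 1 to compound 2 (0.54 log units; beyond the scatter) lies beyond the scatter. Compound 3 `O=C(Nc1sc2c(c1C(=O)NNc1ccc(Br)cc1)CCCCC2)NS(=O)(=O)c1ccccc1` is the next member: ((4-bromophenyl)amino)amino in place of 4-phenylpiperazin-1-yl on a carbonyl carbon. Going by the values given here, the only measured step that bears on this position is the one from compound 1 to compound 2, which shows that leaving the aminoamino group for 4-phenylpiperazin-1-yl weakened inhibition by a modest amount. Compound 3 returns to an aminoamino-type group, now bearing a 4-bromophenyl, so a step back toward the number of compound 1 is expected, roughly a 2.8-fold lower number from compound 2 to compound 3 (0.44 log units; beyond the scatter) in this assay. For compound 3 the expected value is 13000 nM, within 4000 nM to 40000 nM.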

Compound 3, concentration for 50% growth inhibition: 11500 nM
The estimate for compound 3 lay 1.1-fold (0.05 log units) above the measured number; the measured number falls inside the stated range.
By their numbers in this assay, from the lowest: compounds 1 and 3 (each within the scatter of the next); then compound 2.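

Working notes on the position. In this assay the move to ((4-bromophenyl)amino)amino gives a 3.1-fold lower number from compound 2 to compound 3 (0.50 log units; beyond the scatter), so an aromatic ring on this group does not by itself go with the weaker number of compound 2, since compound 2 and compound 3 both carry one. Placing 4-bromophenyl on the amine nitrogen gives a 1.1-fold higher number from compound 1 to compound 3 (0.04 log units; within the scatter), so in these two compounds the position takes that ring with no change beyond the scatter. No measurement at hand accounts for the gap between 4-phenylpiperazin-1-yl and the aminoamino-type groups.

Going by these compounds, whether the bromine matters stays open, a plain phenyl or a 4-methoxyphenyl on the same amine nitrogen being the direct comparison. On these data alone, it is also open whether a morpholine or an unsubstituted piperazine on the carbonyl carbon would fall with compound 2 or with compound 1 and compound 3.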